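Swapping one diazine ring for another on a fused core

A few compounds are considered here, and "the series" means these few. Any claim that something is new, unique, unknown or untested is made for them only; others in the source may bear on it.

Measured compounds:
compound 1, `Fc1ccc2nc(-c3cnco3)n(C3CC3)c2c1`: in an assay on cells for inhibition of cytochrome P450 11B2, mitochondrial (Homo sapiens), read by HPLC, with a stated time of 90 min (a higher number here means a weaker inhibitor, a lower number a stronger inhibitor), compound 1 gives > 10000 nM; this value is a limit of the assay, not a number.
compound 2, `Fc1ccc2nc(-c3cnccn3)n(C3CC3)c2c1`: in this assay compound 2 gives 541 nM.

Going by the values given here, compound 2 therefore stands as the only compound with a measured number in this assay; the other value is a limit. Among the compounds with values here, the one measured step, an at least 18-fold lower number from compound 1 to compound 2 (1.26 log units; beyond the scatter), is large, and it rests on the fact that compound 1 sits at the limit of > 10000 nM in this assay, at which 1 of the 2 values shown sits.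

Compound 3, `Fc1ccc2nc(-c3cccnn3)n(C3CC3)c2c1`, differs from compound 2 by pyridazin-3-yl in place of pyrazin-2-yl on an aromatic carbon. The measured step does not involve pyridazin-3-yl, so it gives no direct guide; it only shows that the ring at this position can shift the number strongly. Since pyrazin-2-yl and pyridazin-3-yl have the same atoms in the same kind of ring, compound 3 is expected to stay close to compound 2, with the estimated step of a 1.0-fold higher number from compound 2 to compound 3 (0.01 log units; within the scatter) within the scatter. The estimate for compound 3 in this assay is 550 nM, with a range from 150 nM to 2000 nM.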

Compound 3, half-maximal inhibitory concentration: 412 nM
The estimate for compound 3 lay 1.3-fold (0.13 log units) above the measured number; low and high end bracket the measured number.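

Pyrazin-2-yl and pyridazin-3-yl hold the same atoms in the same kind of ring, joined differently, and in this assay exchanging one for the other gives a 1.3-fold lower number from compound 2 to compound 3 (0.12 log units; within the scatter), so this assay does not separate the two rings. Going by these compounds alone, the earlier compounds showed only that the ring at this position can matter a great deal; this pair adds that, for these two rings, rearranging the atoms within a six-membered aromatic ring with 2 hetero atoms leaves the numbers within the scatter of each other. Replacing 1,3-oxazol-5-yl with pyridazin-3-yl gives an at least 24-fold lower number from compound 1 to compound 3 (1.38 log units; beyond the scatter), and the true size of that step stays unknown because one end of it is a limit: the limit of > 10000 nM in this assay, at which 1 of the 3 values shown sits.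

The compounds shown leave open how a ring with a single nitrogen, such as pyridin-2-yl, or a plain phenyl ring would behave at this position, and whether a methyl group or an amine on the pyridazin-3-yl ring would move the number in either direction. They also say nothing about the cyclopropyl group or the fluorine on the shared core, which stay the same in all three compounds.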